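Thiosemicarbazone series: antiproliferative readings, one substituent change

The compounds below may be only part of what the source reports. "The series", "measured", "known", "first", "only" and "open" are said of these compounds alone.

Measured compounds:
compound 1 `S=C(N/N=C/c1ccc2ccccc2n1)Nc1ccc(Br)cc1`: 54400 nM
compound 2 `NC(=S)N/N=C/c1cc2ccccc2s1`: 99200 nM

In a functional assay on HT-29 cells (Homo sapiens) for antiproliferative activity, read by sulforhodamine B assay, with a stated time of 72 h (on this read-out lower numbers stand for stronger inhibition and higher numbers for weaker inhibition), compound 1 gives 54400 nM, the lower of the two numbers shown. In this assay compound 2 gives 99200 nM, which lies within the scatter of the reading for compound 1, so the two values cannot be ordered. Within the data shown here, no step between measured compounds differing in a single place is available, and compound 1 and compound 2 differ in more than one place, so their pair shows only its two values.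

Compound 3 `COc1cccc(NC(=S)N/N=C/c2ccc3ccccc3n2)c1` is not yet measured in this assay. It differs from compound 1 as follows: 3-methoxyphenyl in place of 4-bromophenyl on an amide-type nitrogen. Among the measured compounds shown here, no measured step speaks to this change. The step from compound 1 to compound 3 is expected to be small, with no clear direction beyond the scatter, giving an estimated 1.1-fold higher number from compound 1 to compound 3 (0.04 log units; within the scatter). For compound 3 in this assay the estimate is 60000 nM, with a range from 25000 nM to 150000 nM.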

Compound 3, half-maximal inhibitory concentration: 82400 nM
Compound 3: middle estimate off by 1.4-fold (0.14 log units), on the low side, within the range that was stated.
By their numbers in this assay, from the lowest: compounds 1, 3 and 2 (each within the scatter of the next).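

Among these compounds, the first step at this position, on the amide-type nitrogen whose other neighbour is the thiocarbonyl carbon, reads in this assay as a 1.5-fold higher number from compound 1 to compound 3 (0.18 log units; within the scatter), so 4-bromophenyl and 3-methoxyphenyl cannot be told apart on this read-out. The substituent and its place on the ring change together in this exchange, so the step cannot be assigned to either one alone, and it gives only a first sign that this position tolerates the change. Nothing available explains the size of the step.

Still open, as far as these compounds go, is whether 3-bromophenyl or 4-methoxyphenyl, which would separate substituent from ring place, would read differently from compound 1. Also open, from the compounds shown here alone, is whether unsubstituted phenyl, a carboxylic acid on the ring or a longer alkyl chain on this nitrogen would move the reading beyond the scatter.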